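The source may report more compounds than this note shows. Statements on the series, on what has been measured and on what is new or still open speak of the compounds shown alone.

In an ADME assay on MCF7 cells (Homo sapiens) for cytotoxicity, read by MTT assay, with a stated time of 72 h (a lower number here means a stronger inhibitor of growth, a higher number a weaker inhibitor of growth), compound 1 (`CCCCCCCCCCNC(=O)C1C(C(=O)O)[C@@H]2CC[C@H]1O2`) gives 10000 nM and stands level with the other two measured compounds. Compound 2 (`CCOC(=O)c1cn[nH]c1NC(=O)C1C(C(=O)O)[C@@H]2CC[C@H]1O2`) gives 10000 nM and compound 3 (`Cn1ccc2cc(CNC(=O)C3C(C(=O)O)[C@@H]4CC[C@H]3O4)ccc21`) gives 10000 nM as well, so the three cannot be told apart at the digits shown. Compound 4 (`CCCCNC(=O)C1C(C(=O)O)[C@@H]2CC[C@H]1O2`) has not yet been measured. Its difference from compound 1 (hydrogen in place of hexyl on a saturated chain carbon, four bonds along the chain from an amide-type nitrogen) is hydrogen in place of hexyl on a saturated chain carbon, four bonds along the chain from an amide-type nitrogen. For the measured compounds named here, no measured pair in this small set differs in one place only, so the size of this step cannot be read directly from the data. Compound 3 at 10000 nM and compound 1 at 10000 nM show no spread despite their unlike side groups, so no step beyond the scatter is expected in this assay for this shortening of the chain. The estimated 1.2-fold higher number from compound 1 to compound 4 (0.08 log units; within the scatter) is expected to remain within the scatter. Compound 4 is expected at 12000 nM with a range of 6000 nM to 30000 nM on this estimate.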

Compound 4, concentration for 50% growth inhibition: 10000 nM
The estimate for compound 4 lay 1.2-fold (0.08 log units) above the measured number; measured number inside the range.
By their numbers in this assay, from the lowest: compounds 1, 2, 3 and 4 (each within the scatter of the next).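

With compound 4, the set gains its first pair that differs in one place: in this assay, hydrogen in place of hexyl on a saturated chain carbon, four bonds along the chain from an amide-type nitrogen, gives no change at the digits printed from compound 1 to compound 4 (within the scatter). For the compounds shown here, this shows directly what the earlier compounds, none of which formed such a pair, could not: at this position, the hexyl part of the chain can be removed with no step beyond the scatter. Nothing measured here speaks to the reason for this result. The compounds shown leave open whether a chain longer than that of compound 1 would give a step beyond the scatter. They also leave open whether an amine or a carboxylic acid at the end of the chain of compound 4 would do so.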